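Does a benzofuran change a silent series?

A few compounds are considered here, and "the series" means these few. Any claim that something is new, unique, unknown or untested is made for them only; others in the source may bear on it.

Measured so far in a functional assay on A549 cells (Homo sapiens), read by MTT assay, with a stated time of 72 h (a lower number here means a stronger inhibitor, a higher number a weaker inhibitor), each value a limit:
- compound 1 `Cc1ncnc2c1c(-c1cc3ccccc3o1)cn2[C@@H]1O[C@H](CO)[C@@H](O)[C@H]1O`: > 20000 nM
- compound 2 `COc1nc(N)nc2c1c(-c1ccco1)cn2[C@@H]1O[C@H](CO)[C@@H](O)[C@H]1O`: > 20000 nM
- compound 3 `COc1nc(N)nc2c1c(-c1ccoc1)cn2[C@@H]1O[C@H](CO)[C@@H](O)[C@H]1O`: > 20000 nM

Compound 3 stands at a limit rather than at a number: in this assay compound 3 gives > 20000 nM. The three readings share this one result: the limit of > 20000 nM in this assay, at which 3 of the 3 values shown sit.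

The next compound, compound 4 `COc1nc(N)nc2c1c(-c1cc3ccccc3o1)cn2[C@@H]1O[C@H](CO)[C@@H](O)[C@H]1O`, keeps the core of compound 3 and changes a single group: 1-benzofuran-2-yl in place of furan-3-yl on an aromatic carbon. The larger group adds a six-membered aromatic ring of carbon only to the furan-type ring.

Within the data shown here, the only measured step, a step that the two limits leave unreadable from compound 2 to compound 3, puts furan-3-yl in place of furan-2-yl, and it gives no size to carry over. The closest guide is compound 1, which already bears 1-benzofuran-2-yl on a core of its own. Compound 1 still reads as a limit, > 20000 nM.

On that evidence, no step beyond the usual scatter is expected in this assay, and another limit is the likeliest reading. The estimated change is a number no higher from compound 3 to compound 4 (the limit leaves the size open). For compound 4 the expected value is 20000 nM, with an estimated range of 7000 nM to 40000 nM.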

Compound 4, half-maximal inhibitory concentration: > 20000 nM
Compound 4: no number, only a limit; the forecaster's own chance of this, stated with the estimate: 75%; the middle value sits exactly at the limit.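

In this assay compound 4 gives > 20000 nM as a limit and not a number. The steps to compound 4 from compound 2 and from compound 3 cannot be read, and all four compounds share one result: the limit of > 20000 nM in this assay, at which 4 of the 4 values shown sit.

The compounds shown leave open how strongly any of them, if at all, inhibits in this assay and whether swapping these groups changes that.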